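The source may report more compounds than this note shows. Statements on the series, on what has been measured and on what is new or still open speak of the compounds shown alone.

In a functional assay on DU-145 cells (Homo sapiens) for inhibition, read by trypan blue exclusion, with a stated time of 96 h (on this read-out higher numbers stand for weaker inhibition of growth and lower numbers for stronger inhibition of growth), compound 3 `O=C(/C(=C/c1ccc(Cl)cc1)Cc1c[nH]c2ccccc12)c1ccc(Cl)cc1Cl` gives 10000 nM. Compound 1 `O=C(/C(=C\c1ccc(O)cc1)S(=O)(=O)Cc1ccc(Cl)c(Cl)c1)c1ccc(Cl)cc1` gives 10000 nM, which sits level with compound 3 within the scatter, so these two share the lowest of the three numbers. Compound 2 `Cc1ccc(S(=O)(=O)/C(=C/c2sccc2C)C(=O)c2ccc(Br)cc2)cc1` gives 25000 nM, a higher number that lies beyond the scatter from compound 3. For the measured compounds named here, no single-point step between measured compounds is available here.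

Compound 4 `O=C(/C(=C/c1ccc(Cl)cc1)Cc1ccc(Cl)c(Cl)c1)c1ccc(Cl)cc1Cl` differs from compound 3 by 3,4-dichlorophenyl in place of 1H-indol-3-yl on a saturated chain carbon bound to a double-bonded chain carbon. Since compound 1, which also carries a 3,4-dichlorophenyl group, gives 10000 nM, the step from compound 3 to compound 4 is expected to be no change at the digits printed from compound 3 to compound 4 (within the scatter), not beyond the scatter in either direction. Compound 4 is therefore estimated at 10000 nM, with a range from 4000 nM to 25000 nM.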

Compound 4, concentration for 50% growth inhibition: 1000 nM
Compound 4: the middle estimate sits 10-fold (1.00 log units) above what was measured; the whole stated range lies above it.
By their numbers in this assay, from the lowest: compound 4; then compounds 1 and 3 (each within the scatter of the next); then compound 2.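

In this assay, 3,4-dichlorophenyl in place of 1H-indol-3-yl on a saturated chain carbon bound to a double-bonded chain carbon gives a 10-fold lower number from compound 3 to compound 4 (1.00 log units; beyond the scatter) and nothing else in the molecule changes. For the compounds shown here, this is the first pair in the set to show that the group at this place can shift inhibition of growth well beyond the scatter. Nothing measured here explains why the number falls.

As far as these compounds go, it remains open whether a plain phenyl group, without chlorine, or a carboxylic acid at this place would keep the lower number. From the compounds shown here alone, it is also open whether the same change would give a similar step on a different core.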